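Adding a fluorine to the indole of compound 3

The compounds below may be only part of what the source reports. "The series", "measured", "known", "first", "only" and "open" are said of these compounds alone.

Compound 3 `COc1cc(N(C)CCN(C)C)c(NC(=O)/C=C\C(C)C)cc1Nc1nc(C)cc(-c2cn(C)c3ccccc23)n1` is one of three close relatives measured in a functional assay on NCI-H1975 cells (Homo sapiens) for antiproliferative activity, read by MTT assay, with a stated time of 72 h; on this read-out higher numbers stand for weaker inhibition and lower numbers for stronger inhibition. In this assay compound 3 gives 1230 nM. Compound 1 `COc1cc(N(C)CCN(C)C)c(NC(=O)/C=C\C(C)C)cc1Nc1nccc(-c2cn(C)c3ccccc23)n1` gives 1820 nM, and compound 2 `CC/C=C\C(=O)Nc1cc(Nc2nc(C)cc(-c3cn(C)c4ccccc34)n2)c(OC)cc1N(C)CCN(C)C` gives 1990 nM. The step of a 1.5-fold lower number from compound 1 to compound 3 (0.17 log units; within the scatter) and the step of a 1.6-fold lower number from compound 2 to compound 3 (0.21 log units; within the scatter) are both within the scatter, so the three numbers cannot be told apart on this evidence.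

Compound 4 `COc1cc(N(C)CCN(C)C)c(NC(=O)/C=C\C(C)C)cc1Nc1nc(C)cc(-c2cn(C)c3ccc(F)cc23)n1` differs from compound 3 by one change: fluoro in place of hydrogen on an aromatic carbon. Neither measured step touches this part of the molecule; one changed the shared core and the other the chain of the amide, and both stayed within the scatter. There is therefore nothing here to suggest that a single fluorine on the indole would move the number beyond the scatter in either direction, and the expected step of a 1.1-fold lower number from compound 3 to compound 4 (0.05 log units; within the scatter) is small. Compound 4 is estimated at 1100 nM, with a range from 400 nM to 3000 nM.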

Compound 4, half-maximal inhibitory concentration: 8520 nM
Beside the measured number, compound 4's estimate is 7.7-fold (0.89 log units) below it; measured number above the stated range.
By their numbers in this assay, from the lowest: compounds 3, 1 and 2 (each within the scatter of the next); then compound 4.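

In this assay a single fluorine gives a 6.9-fold higher number from compound 3 to compound 4 (0.84 log units; beyond the scatter) and so becomes the only step shown that lies beyond the scatter. The earlier steps shown here, on the shared core and on the chain of the amide, could not be told apart from repeat-to-repeat variation, whereas this one shows that the number responds to a change of just one heavy atom on the six-membered aromatic ring of the indole. No measurement available here explains the size of this step.

On these data alone, it remains open whether this step belongs to fluorine itself or would appear with any group at this carbon, such as chlorine, a methoxy group or a nitrile. As far as these compounds go, it is also open whether the 5-fluoro-1-methyl-1H-indol-3-yl group would have the same effect on the core of compound 1.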